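The source may hold more compounds than are shown below. What is called first, only, known or untested is meant among the compounds shown, and "the series" means these compounds.

Of the compounds shown here, three of one shared core have so far been tested in a functional assay on Raji cells (Homo sapiens) for antiproliferative activity, read by CCK-8 assay, with a stated time of 24 h; a lower number here means a stronger inhibitor, a higher number a weaker inhibitor. Compound 1 `C=CC(=O)Nc1cccc(Nc2nc(N)nc(Nc3ccc(OCCOC)cc3)n2)c1` gives 18300 nM in this assay. Compound 2 `CC#CC(=O)Nc1cccc(Nc2ncnc(Nc3ccc(C(=O)N4CCCCC4)cc3)n2)c1` gives 4620 nM in this assay, and compound 3 `C=CC(=O)Nc1cccc(Nc2ncnc(Nc3ccc(-c4ccc(F)nc4)cc3)n2)c1` gives 3250 nM in this assay. Among these three numbers compound 2 stands second highest: its number lies close to that of compound 3, a gap within the usual scatter, while compound 1 sits well above it, a gap beyond the scatter.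

Compound 4 `C/C=C/C(=O)Nc1cccc(Nc2ncnc(Nc3ccc(C(=O)N4CCCCC4)cc3)n2)c1` has not yet been measured. It differs from compound 2 at a single spot: prop-1-en-1-yl in place of prop-1-yn-1-yl on a carbonyl carbon. Everything else in the molecule stays the same. Among the measured compounds shown here, no measured pair here shows what this particular swap does, so any expectation rests on the small size of the change alone. The step expected, a 1.3-fold higher number from compound 2 to compound 4 (0.11 log units; within the scatter), is a small one, lying within the scatter and with no clear direction. Compound 4 is therefore estimated at 6000 nM, with a range from 2000 nM to 18000 nM.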

Compound 4, half-maximal inhibitory concentration: 13800 nM
The estimate for compound 4 lay 2.3-fold (0.36 log units) below the measured number; the measured number falls inside the stated range.
By their numbers in this assay, from the lowest: compounds 3 and 2 (each within the scatter of the next); then compounds 4 and 1 (each within the scatter of the next).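

Among the compounds shown here, this is the first pair in the set that differs only at this position, the group on the carbonyl carbon of the amide, and in this assay the change from prop-1-yn-1-yl to prop-1-en-1-yl gives a 3.0-fold higher number from compound 2 to compound 4 (0.48 log units; beyond the scatter). Swapping a triple bond for a double bond, with the same count of carbons and no hydrogen-bond donors or acceptors gained, is thus enough to weaken the compound measurably, so this position is sensitive to small edits. Nothing available here explains the shift.

On these data alone, it remains open how a saturated propyl chain, a longer chain or an amine on the chain would fare at this carbonyl carbon. As far as these compounds go, it is also open whether the same swap gives a step of similar size when the rest of the molecule is different.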